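The source may report more compounds than this note shows. Statements on the series, on what has been measured and on what is new or still open speak of the compounds shown alone.

Working notes on the acylguanidine series. The reference is a functional assay for inhibition of sodium/hydrogen exchanger (Oryctolagus cuniculus); a higher number here means a weaker inhibitor, a lower number a stronger inhibitor. Compound 3 `CCc1cc(Oc2cccnc2)c(S(C)(=O)=O)cc1C(=O)N=C(N)N` gives 27 nM and stands second highest of the three numbers; compound 1 `Cc1cc(N2CCCCC2)c(S(C)(=O)=O)cc1C(=O)N=C(N)N` gives 21 nM, within scatter of it, while compound 2 `CS(=O)(=O)c1cc(C(=O)N=C(N)N)c(N2CCCCC2)cc1N1CCCCC1` gives 1000 nM, well beyond. Among the measured compounds shown here, the only measured step, a 48-fold higher number from compound 1 to compound 2 (1.68 log units; beyond the scatter), concerns a different position and bears on the present change only loosely. Compound 4 `CCc1cc(N2CCCCC2)c(S(C)(=O)=O)cc1C(=O)N=C(N)N` arises from compound 3 by piperidin-1-yl in place of (pyridin-3-yl)oxy on an aromatic carbon. For the measured compounds named here, no measured step covers this swap; the closest hint is compound 1, which already carries piperidin-1-yl there and gives 21 nM. For compound 4 the step of a 1.2-fold lower number from compound 3 to compound 4 (0.09 log units; within the scatter) is therefore expected to stay within scatter. Compound 4 is estimated at 22 nM, range 9 nM to 55 nM.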

Compound 4, half-maximal inhibitory concentration: 25 nM
Beside the measured number, compound 4's estimate is 1.1-fold (0.06 log units) below it; measured number inside the range.
By their numbers in this assay, from the lowest: compounds 1, 4 and 3 (each within the scatter of the next); then compound 2.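

In this assay, the exchange at the carbon ortho to the methylsulfonyl group gives a 1.1-fold lower number from compound 3 to compound 4 (0.03 log units; within the scatter), so with ethyl on the ring, an aromatic and a non-aromatic six-membered ring are not told apart there. Among the compounds shown here, with piperidin-1-yl in place, the change from methyl to ethyl gives a 1.2-fold higher number from compound 1 to compound 4 (0.08 log units; within the scatter), whereas the only large new step is a 40-fold lower number from compound 2 to compound 4 (1.60 log units; beyond the scatter), which concerns the ethyl carbon instead. Nothing available gives a reason for these steps. As far as these compounds go, whether an open-chain group such as methoxy, a primary amine or a carboxylic acid would hold the number at this carbon stays open. So does whether a longer chain than ethyl would be tolerated.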